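Working notes on the chain-end exchange toward compound 4

This account rests on a few compounds, and the source may have more. Where it says the series, first, only, none or still open, it means among the compounds named here.

Measured so far in a functional assay on the whole organism (stomach) with Rattus norvegicus as the target; on this read-out lower numbers stand for an effect already at smaller amounts and higher numbers for an effect only at larger amounts of compound:
Compound 1, `CC/N=C(/NC#N)NCCCn1nc(-c2ccccc2)ccc1=O`, gives 78.3 mg/kg.
Compound 2, `N/C(S)=N/CCCCn1nc(-c2ccccc2)ccc1=O`, gives 36.3 mg/kg.
Compound 3, `CC/N=C(\S)NCCCCn1nc(-c2ccccc2)ccc1=O`, gives 37.2 mg/kg.

Compound 3 stands second highest of the three numbers; it sits within the scatter of compound 2 and is separated from compound 1 by a 2.1-fold lower number from compound 1 to compound 3 (0.32 log units; beyond the scatter). Compound 4, `N#CNC(=N)NCCCn1nc(-c2ccccc2)ccc1=O`, is not yet measured. The change is a group of 6 heavy atoms (2 carbon, 4 nitrogen; no ring) in place of a group of 7 heavy atoms (4 carbon, 2 nitrogen, 1 sulfur; no ring), on a saturated chain carbon, three bonds along the chain from an aromatic nitrogen. Within the data shown here, the group that enters closely resembles the one in compound 1, and the chain length matches compound 1, so the step largely reverses a 2.1-fold lower number from compound 1 to compound 3 (0.32 log units; beyond the scatter). The step of a 1.0-fold higher number from compound 2 to compound 3 (0.01 log units; within the scatter) shows that the ethyl carried by compound 3 made no difference beyond the scatter. A modest move to a higher number in this assay is therefore expected. Compound 4 is estimated at 72 mg/kg, range 36 mg/kg to 145 mg/kg. That estimate means an expected step of a 1.9-fold higher number from compound 3 to compound 4 (0.29 log units; within the scatter).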

Compound 4, dose for half-maximal effect: > 100 mg/kg
Compound 4 gave a limit, no number; the forecaster's own chance of this, stated with the estimate: 5%; middle value at least 1.3-fold (0.14 log units) from the limit.
By their numbers in this assay, from the lowest: compounds 2 and 3 (each within the scatter of the next); then compound 1. At a limit, above all of these: compound 4.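

In this assay compound 4 gives > 100 mg/kg as a limit and not a number. Exchanging the sulfur-bearing chain end gives an at least 2.6-fold higher number from compound 3 to compound 4 (0.42 log units; beyond the scatter) and an at least 2.7-fold higher number from compound 2 to compound 4 (0.44 log units; beyond the scatter) and so both floors lie beyond the scatter, though chain length and end group change together in these two steps. Losing the ethyl at the amine nitrogen gives an at least 1.2-fold higher number from compound 1 to compound 4 (0.10 log units; that floor lies within the scatter) and that floor lies within the scatter, so this step does not settle whether the ethyl matters.

The compounds shown leave open how the sulfur-bearing end group behaves on the shorter chain. They also leave open whether an amine at the chain end would keep the lower numbers of compound 2 and compound 3.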